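From isopropyl to ethyl at the assay limit

This account rests on a few compounds, and the source may have more. Where it says the series, first, only, none or still open, it means among the compounds named here.

Measured so far:
Compound 1 `CCc1c(C)c(O)c(C)c(O[C@@H]2O[C@H](CO)[C@@H](O)[C@H](O)[C@H]2O)c1C(=O)SC`: > 40000 nM
Compound 2 `CSC(=O)c1c(O[C@@H]2O[C@H](COC(C)=O)[C@@H](O)[C@H](O)[C@H]2O)c(C)c(O)c(C)c1C(C)C`: > 40000 nM

In a functional assay on MDA-MB-231 cells (Homo sapiens) for cytotoxicity, read by sulforhodamine B assay, with a stated time of 72 h (on this read-out lower numbers stand for stronger inhibition and higher numbers for weaker inhibition), compound 2 gives > 40000 nM, which is a limit of the assay and not a number. Compound 1 gives > 40000 nM, also a limit. The only mark that the data offer for compound 2 is therefore (the limit of > 40000 nM in this assay, at which 2 of the 2 values shown sit).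

Compound 3 `CCc1c(C)c(O)c(C)c(O[C@@H]2O[C@H](COC(C)=O)[C@@H](O)[C@H](O)[C@H]2O)c1C(=O)SC` has not been measured yet. It differs from compound 2 in one place, isopropyl to ethyl: hydrogen in place of methyl on a saturated chain carbon bound to an aromatic carbon and a saturated chain carbon.

Among the compounds with values here, no measured step shows what this change does. In this assay no step beyond the usual scatter is expected, in either direction. This expectation rests on compound 2, whose value > 40000 nM is a limit. The expected step is a number no higher from compound 2 to compound 3 (the limit leaves the size open). The estimate for compound 3 is 40000 nM, with an expected range from 20000 nM to 80000 nM.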

Compound 3, half-maximal inhibitory concentration: 16000 nM
For compound 3 the middle estimate is 2.5-fold (0.40 log units) above the measured one; measured number below the stated range.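

In this assay compound 3 is the only one of the three to give a true number, 16000 nM, which shows that this position can respond to a change. Shortening isopropyl to ethyl, with hydrogen in place of methyl on a saturated chain carbon bound to an aromatic carbon and a saturated chain carbon, gives an at least 2.5-fold lower number from compound 2 to compound 3 (0.39 log units; beyond the scatter). The acetyl on an oxygen on a saturated carbon matters too, with an at least 2.5-fold lower number from compound 1 to compound 3 (0.39 log units; beyond the scatter), so among these three only the compound carrying both ethyl and acetyl gives a number.

On these data alone, both steps are minimum sizes, and their true sizes stay open, as each starts from a limit: the limit of > 40000 nM in this assay, at which 2 of the 3 values shown sit. As far as these compounds go, how a longer chain such as butyl, or an amine, would behave at this place remains open.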